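A few compounds are considered here, and "the series" means these few. Any claim that something is new, unique, unknown or untested is made for them only; others in the source may bear on it.

Compound 1 `CC1(C)CC(NC(=S)Nc2cccc(C#N)c2)c2cc(Br)ccc2O1`: 6000 nM
Compound 2 `CC1(C)CC(NC(=S)NCc2ccccc2)c2cc(Br)ccc2O1`: 29000 nM
Compound 3 `CC1(C)CC(NC(=S)Nc2ccc(Cl)cc2)c2cc(Br)ccc2O1`: 7000 nM

In a functional assay on U-373MG ATCC cells (Homo sapiens) for inhibition, read by MTT assay, with a stated time of 72 h (on this read-out higher numbers stand for weaker inhibition and lower numbers for stronger inhibition), compound 3 gives 7000 nM, which is level with one neighbour within the scatter, a 1.2-fold higher number from compound 1 to compound 3 (0.07 log units; within the scatter), and clear of the other, a 4.1-fold lower number from compound 2 to compound 3 (0.62 log units; beyond the scatter). Compound 4 `CC1(C)CC(NC(=S)Nc2ccccc2Cl)c2cc(Br)ccc2O1` keeps the same atoms, joined differently: 2-chlorophenyl in place of 4-chlorophenyl on an amide-type nitrogen, with 2-chlorophenyl in place of 4-chlorophenyl on an amide-type nitrogen. For the measured compounds named here, no measured step moves the chlorine. The nearest evidence is the exchange of one substituted phenyl for another, a 1.2-fold higher number from compound 1 to compound 3 (0.07 log units; within the scatter), which stayed within the scatter, while only the benzyl change, a 4.8-fold higher number from compound 1 to compound 2 (0.68 log units; beyond the scatter), went beyond it. No step beyond the scatter is therefore expected, and the estimate is a 1.1-fold higher number from compound 3 to compound 4 (0.06 log units; within the scatter). Compound 4 is expected near 8000 nM, within an estimated range of 3500 nM to 18000 nM.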

Compound 4, half-maximal inhibitory concentration: 34000 nM
The estimate for compound 4 lay 4.3-fold (0.63 log units) below the measured number, outside the stated range (above it).
By their numbers in this assay, from the lowest: compounds 1 and 3 (each within the scatter of the next); then compounds 2 and 4 (each within the scatter of the next).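

Where the chlorine sits on the phenyl group on the amide-type nitrogen matters here, a sensitivity that the exchange of 3-cyanophenyl for 4-chlorophenyl did not reveal: 2-chlorophenyl in place of 4-chlorophenyl gives a 4.9-fold higher number from compound 3 to compound 4 (0.69 log units; beyond the scatter). The same change separates it from the cyanophenyl analogue, with a 5.7-fold higher number from compound 1 to compound 4 (0.75 log units; beyond the scatter), while it leaves the compound level with the benzyl analogue, with a 1.2-fold higher number from compound 2 to compound 4 (0.07 log units; within the scatter). Nothing measured here accounts for this shift. The compounds shown leave open whether a methyl group or a fluorine atom in place of the chlorine of 2-chlorophenyl would give a similar number.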